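Methyl on the pyridine ring of compound 1: expected maximal response

The source may report more compounds than this note shows. Statements on the series, on what has been measured and on what is new or still open speak of the compounds shown alone.

Among the measured compounds shown here, compound 1 `CN1CCC[C@H]1COc1cccnc1` gives the highest of the two numbers measured so far in an assay on K177 cells with Neuronal acetylcholine receptor; alpha4/beta2 (Homo sapiens) as the target (a higher number here means a larger maximal response, a lower number a smaller maximal response), namely 100%. Its nearest neighbour is compound 2 `CCc1cncc(OC[C@@H]2CCCN2C)c1`, which in this assay gives 33.7%; that change, a number 66.3 percentage points lower from compound 1 to compound 2 (beyond the scatter), came from an ethyl in place of a hydrogen on an aromatic carbon. Compound 3 `Cc1ccc(OC[C@@H]2CCCN2C)cn1` differs from compound 1 in one place: methyl in place of hydrogen on an aromatic carbon, on an aromatic carbon of the six-membered ring with one nitrogen, next to the ring nitrogen and para to the group of eight heavy atoms. For the measured compounds named here, only the step from compound 1 to compound 2 bears on this change, and it was large and downward, though it concerned a larger group at another aromatic carbon. A smaller drop is therefore expected, a number 40 percentage points lower from compound 1 to compound 3 (beyond the scatter). Compound 3 is estimated to give 60% in this assay, within 25% to 100%.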

Compound 3, largest response reached (reported as maximum), in percent of the reference or control that the assay uses: 54.4%
For compound 3 the middle estimate is 5.6 percentage points above the measured one; low and high end bracket the measured number.
By their numbers in this assay, from the lowest: compound 2; then compound 3; then compound 1.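

In this assay, a methyl on the aromatic carbon next to the ring nitrogen and para to a group of 8 heavy atoms gives a number 45.6 percentage points lower from compound 1 to compound 3 (beyond the scatter) and the step counts as large. Among the compounds shown here, until now the only step away from compound 1 was the ethyl at another aromatic carbon, so this is the first sign that a group of just 1 heavy atom, at this place, is enough to lower the maximal response beyond the scatter. No measurement at hand accounts for this fall.

Going by these compounds, it remains open whether a fluorine, a methoxy group or an amine on this same carbon would lower the maximal response as methyl does. On these data alone, it is equally open how a methyl would fare on the carbon that carries ethyl in compound 2.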